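The source may report more compounds than this note shows. Statements on the series, on what has been measured and on what is new or still open speak of the compounds shown alone.

Of the compounds shown here, two with a shared core have been measured in a functional assay on HCT-116 cells (Homo sapiens) for cytotoxicity, read by sulforhodamine B assay, with a stated time of 72 h; on this read-out lower numbers stand for stronger inhibition and higher numbers for weaker inhibition. Compound 1 `Cc1ccc(-c2cc(C(=O)Nc3ccncc3)nn2-c2ccc3ccccc3n2)cc1` gives 8100 nM, and compound 2 `COc1ncccc1NC(=O)c1cc(-c2ccc(C)cc2)n(-c2ccc3ccccc3n2)n1` gives 15700 nM. These two numbers lie within the usual scatter of each other, so no order between them can be claimed.

Compound 3 `Cc1ccc(-c2cc(C(=O)Nc3ncc(Br)cc3Br)nn2-c2ccc3ccccc3n2)cc1` keeps the shared core and differs from compound 2 at one place, on the amide-type nitrogen, where 3,5-dibromopyridin-2-yl takes the place of 2-methoxypyridin-3-yl: 3,5-dibromopyridin-2-yl in place of 2-methoxypyridin-3-yl on an amide-type nitrogen. Going by the values given here, no measured compound carries the 3,5-dibromopyridin-2-yl group, so the evidence is indirect.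

Among the compounds with values here, only one measured step bears on this change, a swap of one group for another at the same place: a 1.9-fold higher number from compound 1 to compound 2 (0.29 log units; within the scatter). This single step is a thin guide to a different group, and it favours no direction. Going by that step alone, no change beyond the scatter is expected in this assay, although the uncertainty is wide. The expected step is a 1.4-fold lower number from compound 2 to compound 3 (0.15 log units; within the scatter). The estimate for compound 3 is 11000 nM, with an expected range from 3500 nM to 30000 nM.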

Compound 3, half-maximal inhibitory concentration: 9600 nM
Compound 3: the middle estimate sits 1.1-fold (0.06 log units) above what was measured, and the stated range covers the measured number.
By their numbers in this assay, from the lowest: compounds 1, 3 and 2 (each within the scatter of the next).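

At the amide-type nitrogen, a third group, 3,5-dibromopyridin-2-yl, gives no number that can be told apart from those of the two earlier groups in this assay: the steps are a 1.6-fold lower number from compound 2 to compound 3 (0.21 log units; within the scatter) and a 1.2-fold higher number from compound 1 to compound 3 (0.07 log units; within the scatter). Going by these compounds alone, compounds 1, 2 and 3 thus show that this position accepts three differently substituted pyridinyl groups, including one carrying two bromine atoms, without any step beyond the scatter, whereas the earlier pair offered only a single comparison. Nothing measured here gives a reason why these numbers lie so close together.

On these data alone, all three groups at this position are pyridinyl rings, so it remains open whether a plain phenyl ring, a short alkyl chain, or a group bearing an amine or a carboxylic acid on the amide-type nitrogen would move the number beyond the scatter. As far as these compounds go, it also remains open whether a change elsewhere on the shared core would have a larger effect in this assay than the swaps at this nitrogen.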